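The source may hold more compounds than are shown below. What is called first, only, known or untested is meant among the compounds shown, and "the series" means these compounds.

Measured in a functional assay on HeLa cells (Homo sapiens) for antiproliferative activity, read by MTT assay, with a stated time of 72 h; a higher number here means a weaker inhibitor, a lower number a stronger inhibitor:
- compound 1 `CCNC(=O)c1cc(Oc2ccc(NC(=O)c3nn(-c4ccccc4OC(F)(F)F)c(=O)cc3C)cc2)ccn1`: 3990 nM
- compound 2 `CCNC(=O)c1cc(Oc2ccc(NC(=O)c3nn(-c4ccc(Br)cc4F)c(=O)cc3C)cc2)ccn1`: "not active" (no number reported)

Compound 2 stands without a single number, since it is reported only as "not active" (no number reported). Compound 3 `CCNC(=O)c1cc(Oc2ccc(NC(=O)c3nn(-c4ccccc4C)c(=O)cc3C)cc2)ccn1` differs from it in one place: 2-methylphenyl in place of 4-bromo-2-fluorophenyl on an aromatic nitrogen, with 2-methylphenyl in place of 4-bromo-2-fluorophenyl on an aromatic nitrogen. Within the data shown here, no measured step shows what such a change does in this assay, so the size of the step cannot be read from the data. Among the measured compounds shown here, the only number available is that of compound 1, at 3990 nM, so a weak but measurable inhibitor is the expected direction. Compound 3 is estimated at 5000 nM, with an expected range of 1500 nM to 20000 nM.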

Compound 3, half-maximal inhibitory concentration: 27300 nM
Beside the measured number, compound 3's estimate is 5.5-fold (0.74 log units) below it, outside the stated range (above it).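

Methyl in place of trifluoromethoxy on an aromatic carbon gives a 6.8-fold higher number from compound 1 to compound 3 (0.84 log units; beyond the scatter) in this assay and leaves a measurable number, so the value at this position moves with this change. The step between compound 2 and compound 3 cannot be read, since compound 2 has no number. Nothing available explains the step.

The compounds shown leave open how an amine or a carboxylic acid on that aromatic carbon would read. They also leave open whether the bromine or the fluorine of compound 2 goes with its "not active" result.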